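Compound 2 and the Step to Compound 4

The source may hold more compounds than are shown below. What is called first, only, known or untested is meant among the compounds shown, and "the series" means these compounds.

In an ADME assay on HEK293 cells (Homo sapiens) for cytotoxicity, read by reporter gene assay and resazurin assay, with a stated time of 48 h (on this read-out higher numbers stand for lower toxicity in this test and lower numbers for higher toxicity in this test), compound 2 `O=C(Nc1ccc(Sc2nc3ccccc3s2)c(Cl)c1)c1cc(Br)cc(Br)c1O` gives 76000 nM. Compound 3 `O=C(Nc1ccc(Sc2nc3ccccc3s2)cc1)c1cc(Br)cc(Br)c1O` gives 66000 nM, and the two values lie within the scatter of each other: the measured step is a 1.2-fold lower number from compound 2 to compound 3 (0.06 log units; within the scatter), with hydrogen in place of chloro on an aromatic carbon. Compound 1 `O=C(Nc1ccc(Sc2nc3ccccc3s2)c(Cl)c1)c1cccc(Br)c1` gives only a limit of this assay, > 100000 nM.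

The change now in view leads to compound 4 `O=C(Nc1ccc(Sc2nc3ccccc3s2)c(Cl)c1)c1ccccc1O`: 2-hydroxyphenyl in place of 3,5-dibromo-2-hydroxyphenyl on a carbonyl carbon, which puts 2-hydroxyphenyl in place of 3,5-dibromo-2-hydroxyphenyl on a carbonyl carbon. Among the compounds with values here, no measured step isolates this change. The closest is an at least 1.3-fold lower number from compound 1 to compound 2 (0.11 log units; that floor lies within the scatter), which alters the group at the same place, while the step to compound 3 concerns another part of the molecule. Since neither measured step is shown to go beyond the scatter, no step beyond the scatter is expected in this assay. The expected change is a 1.1-fold higher number from compound 2 to compound 4 (0.02 log units; within the scatter). For compound 4 the estimated value is 80000 nM, with an expected range from 35000 nM to 180000 nM.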

Compound 4, half-maximal cytotoxic concentration: 64000 nM
Compound 4: middle estimate off by 1.3-fold (0.10 log units), on the high side; the measured number falls inside the stated range.
By their numbers in this assay, from the lowest: compounds 4, 3 and 2 (each within the scatter of the next). At a limit, above all of these: compound 1.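

Taking both bromine atoms out of the group on the carbonyl carbon gives a 1.2-fold lower number from compound 2 to compound 4 (0.07 log units; within the scatter) in this assay, so at this place the two bromine atoms alone do not shift the number beyond the scatter. The earlier step at this place could not show that, as it changed the bromine atoms and the hydroxy group together. The other new step, an at least 1.5-fold lower number from compound 1 to compound 4 (0.19 log units; that floor lies within the scatter), changes only the substituents on the same ring, but its floor says little, as it rests on a limit: the limit of > 100000 nM in this assay, at which 1 of the 4 values shown sits.

Going by these compounds, it remains open whether a carboxylic acid or an amine in place of the hydroxy group of 2-hydroxyphenyl would move the number beyond the scatter. On these data alone, it also remains open how a single bromine atom on 2-hydroxyphenyl would read.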